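Swapping the ethoxy group of compound 2 for a dimethylcarbamoyl

A few compounds are considered here, and "the series" means these few. Any claim that something is new, unique, unknown or untested is made for them only; others in the source may bear on it.

Of the compounds shown here, three have been measured in an assay on HeLa cells with Bile acid receptor (Homo sapiens) as the target, read by a luciferase reporter, with a stated time of 24 h; on this read-out lower numbers stand for an effect already at smaller amounts and higher numbers for an effect only at larger amounts of compound. Compound 1 `CC(NC(=O)c1ccc(C(C)(C)C)cc1)c1ccc(C(=O)O)cc1` gives 76 nM, compound 2 `CCOc1ccc(CNC(=O)c2ccc(C(C)(C)C)cc2)cc1` gives 160 nM, and compound 3 `O=C(O)c1ccc(CNC(=O)c2ccc3ccccc3c2)cc1` gives 1360 nM. Within this small set, compound 2 holds the second highest number: compound 1 lies a little lower, by a gap beyond the usual scatter, while compound 3 lies far higher, by a gap well beyond the scatter.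

The next compound, compound 4 `CN(C)C(=O)c1ccc(CNC(=O)c2ccc(C(C)(C)C)cc2)cc1`, has not yet been measured in this assay. It differs from compound 2 in one place: dimethylcarbamoyl in place of ethoxy on an aromatic carbon. The ethoxy group leaves and a dimethylcarbamoyl group enters, on the same aromatic carbon.

Within the data shown here, no measured pair in this set shows what such a change does, so the expectation rests only on where compound 2 stands. Compound 4 is expected to stay in the same region as compound 2, with a step from a 1.6-fold higher number from compound 2 to compound 4 (0.19 log units; within the scatter) that is small and, if anything, toward a higher number, quite possibly within the scatter. The estimate for compound 4 is 250 nM, with a likely range from 80 nM to 800 nM.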

Compound 4, half-maximal effective concentration: 170 nM
Compound 4: middle estimate off by 1.5-fold (0.17 log units), on the high side; the range from low to high includes it.
By their numbers in this assay, from the lowest: compound 1; then compounds 2 and 4 (each within the scatter of the next); then compound 3.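

In this assay, among these compounds, this is the first direct look at what a change at this position does, and the step is a 1.1-fold higher number from compound 2 to compound 4 (0.03 log units; within the scatter). On this read-out, ethoxy, with 3 heavy atoms, and dimethylcarbamoyl, with 5 heavy atoms and a double bond outside aromatic rings, cannot be told apart when placed on this aromatic carbon, para to a large group, so this one exchange leaves the result unchanged within the usual scatter despite the larger group. No measurement shown here explains why the two compounds read alike.

This single pair cannot show how much variety the position accepts. Two groups that each carry one hydrogen-bond acceptor and no hydrogen-bond donors are only a narrow sample. A carboxylic acid, an amine or a longer chain on the same aromatic carbon, with the rest of compound 2 kept unchanged, would show whether the read-out stays in this region or moves clearly away from it.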